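A Second Methoxy Group Enters the Core of Compound 1

A few compounds are considered here, and "the series" means these few. Any claim that something is new, unique, unknown or untested is made for them only; others in the source may bear on it.

Of the compounds shown here, two have been measured so far. Compound 1 `COc1ccc2c(c1)CCN(CCCN1CCc3cc(OC)c(OC)cc3C1)C2=O` holds the lower of the two numbers in an assay on membranes from brain (strain Dunkin) for displacement of a labelled ligand from Sigma non-opioid intracellular receptor 1 (Cavia porcellus) (a higher number here means a weaker inhibitor, a lower number a stronger inhibitor), where compound 1 gives 402 nM. Compound 2 `COc1cc2c(cc1OC)CN(CCCN1CCc3cccc(OC)c3C1=O)CC2` gives 1630 nM in this assay, a higher number that lies beyond the usual scatter, so compound 1 is the stronger inhibitor of the pair. Compound 3 `COc1cc2c(cc1OC)CN(CCCN1CCc3cc(OC)c(OC)cc3C1=O)CC2` has not yet been tested. It differs from compound 1 in one place: methoxy in place of hydrogen on an aromatic carbon. Among the measured compounds shown here, no measured pair shows the effect of this particular change, and compound 2 does not share it, so its value offers no direct guide. In the absence of such a step, the expected change is a 1.3-fold lower number from compound 1 to compound 3 (0.13 log units; within the scatter), not beyond the scatter in either direction. Compound 3 is therefore expected to give 300 nM in this assay, with an estimated range from 100 nM to 1000 nM.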

Compound 3, inhibition constant: 2570 nM
Beside the measured number, compound 3's estimate is 8.6-fold (0.93 log units) below it; measured number above the stated range.
By their numbers in this assay, from the lowest: compound 1; then compounds 2 and 3 (each within the scatter of the next).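

Among the compounds shown here, the step gives the first direct reading for this change: in this assay, methoxy in place of hydrogen on this aromatic carbon, ortho to a methoxy group, brings a 6.4-fold higher number from compound 1 to compound 3 (0.81 log units; beyond the scatter). The added group has only 2 heavy atoms, no ring and no net charge, yet the step makes the inhibitor weaker, so this position of the core of compound 1 is sensitive to substitution, at least with methoxy and within this single pair. Nothing available explains why the number rises at this position.

Going by these compounds, it remains open whether a smaller fluorine atom, a hydroxyl group or a larger ethoxy group on the same aromatic carbon would bring a similar step. On these data alone, it is also open whether methoxy here would have the same effect with a longer chain joining the two ring systems.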